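A few compounds are considered here, and "the series" means these few. Any claim that something is new, unique, unknown or untested is made for them only; others in the source may bear on it.

Of the compounds shown here, three of a shared core have been measured in a functional assay on KG-1 cells (Homo sapiens) for cytotoxicity, read by luminescence and CellTiter-Glo, with a stated time of 3 days; a higher number here means a weaker inhibitor, a lower number a stronger inhibitor. Compound 1 `N#Cc1ccc(NC(=O)c2cc(-c3ccncc3)ccc2O)cc1` gives 7990 nM, the highest number of the three. Compound 3 `O=C(Nc1ccc(Cl)cc1Cl)c1cc(F)ccc1O` gives 850 nM, and compound 2 `O=C(Nc1cc(C(F)(F)F)cc(C(F)(F)F)c1)c1cc(Cl)c(F)cc1O` gives 470 nM; both lie well below compound 1, beyond the scatter of this assay, and compound 2 sits furthest from it.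

Compound 4 `N#Cc1ccc(NC(=O)c2cc(C(F)(F)F)ccc2O)cc1` is the next step from compound 1. It differs in one place: trifluoromethyl in place of pyridin-4-yl on an aromatic carbon. The new group sits para to a hydroxy group on the core.

Going by the values given here, no measured pair isolates this exchange, so the expected size rests on the wider set. The two compounds that give the lower numbers carry halogens or trifluoromethyl groups on their aromatic rings, and compound 2, with two trifluoromethyl groups, gives 470 nM. A step toward a lower number, of moderate size and beyond the scatter, is therefore expected, a 3.2-fold lower number from compound 1 to compound 4 (0.50 log units; beyond the scatter). Compound 4 is estimated at 2500 nM, with a range from 800 nM to 8000 nM.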

Compound 4, half-maximal inhibitory concentration: 4810 nM
For compound 4 the middle estimate is 1.9-fold (0.28 log units) below the measured one; the measured number falls inside the stated range.
By their numbers in this assay, from the lowest: compounds 2 and 3 (each within the scatter of the next); then compounds 4 and 1 (each within the scatter of the next).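

In this assay, the exchange of pyridin-4-yl for trifluoromethyl, on the aromatic carbon para to a hydroxy group, amounts to a 1.7-fold lower number from compound 1 to compound 4 (0.22 log units; within the scatter). This first single-place comparison in the set therefore does not separate the two groups: a six-membered aromatic ring and a group with no ring read alike at this position, with the nitrile-bearing remainder of the compound held constant. Nothing available here offers an explanation for this result.

From the compounds shown here alone, whether an amine, a carboxylic acid or a methoxy group at this same position would move the number beyond the scatter from compound 1 remains open. Also open, going by these compounds, is whether the exchange would read alike in a compound carrying chlorine or trifluoromethyl groups in place of the nitrile.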